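The source may report more compounds than this note shows. Statements on the series, on what has been measured and on what is new or still open speak of the compounds shown alone.

Series measured in a functional assay on CEM-SS cells (Homo sapiens) for cytotoxicity; a lower number here means a stronger inhibitor, a higher number a weaker inhibitor:
- compound 1 `Nc1nc2cc(Cl)c(Cl)cc2n1Cc1cc(C(F)(F)F)cc(C(F)(F)F)c1` gives 17000 nM
- compound 2 `Cc1ccc(Cn2c(Cl)nc3cc(Cl)c(Cl)cc32)cc1` gives > 100000 nM (a limit)
- compound 3 `Clc1cc2nc(Br)n(Cc3ccccc3)c2cc1Cl` gives > 100000 nM (a limit)

Within the data shown here, compound 1 is the only member of the series with a numerical value. The other two results sit at the same ceiling, which describes the limit of > 100000 nM in this assay, at which 2 of the 3 values shown sit, and gives no exact reading for either compound.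

Compound 3 therefore stands only as a limit. Compound 3 gives > 100000 nM and this is not a number.

The next compound is compound 4 `Cc1ccc(Cn2c(Br)nc3cc(Cl)c(Cl)cc32)cc1`, which has methyl in place of hydrogen on an aromatic carbon, para to a large group. The counted change is methyl in place of hydrogen on an aromatic carbon.

Among the measured compounds shown here, no measured pair isolates this change, so there is no direct precedent for its size. In this assay no step beyond the scatter is expected, and no direction is favoured. Compound 4 is expected to remain at the limit and may well be reported only as a limit. Compound 2 gives > 100000 nM, also a limit, and this expectation rests on that result.

The estimated change is a number no higher from compound 3 to compound 4 (the limit leaves the size open) and should be read with compound 3 known only as a limit.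

For compound 4 the expected value is 100000 nM, with an estimated range from 40000 nM to 200000 nM.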

Compound 4, half-maximal inhibitory concentration: > 100000 nM
Compound 4 ended at the assay's limit (the forecaster's own chance of this, stated with the estimate: 80%); the middle value sits exactly at the limit.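

No new step can be read from compound 2 to compound 4 or from compound 3 to compound 4, since all three compounds stand only as a limit: the limit of > 100000 nM in this assay, at which 3 of the 4 values shown sit.

In this assay the compounds shown leave open both the size and the direction of methyl in place of hydrogen and of bromo in place of chloro on an aromatic carbon.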